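The source may report more compounds than this note shows. Statements on the series, on what has been measured and on what is new or still open speak of the compounds shown alone.

Of the compounds shown here, three built on one shared core have been tested for how strongly they block a glutathione-handling enzyme. Compound 1 `Cc1cccc2c1N(CC(=O)O)C/C(=C\c1cccc(O)c1)C2=O` gives 75.6% in an assay on HL-60 cells for inhibition of glutathione S-transferase P (Homo sapiens), read by spectrophotometry, tested at 20 uM; a higher number here means more inhibition at the concentration tested (going by the name of the read-out), a lower number less inhibition. Compound 2 `Cc1ccc2c(c1)C(=O)/C(=C/c1ccc(F)cc1)CN2CC(=O)O` gives 16.1% in this assay. Compound 3 `Cc1cccc2c1N(CC(=O)O)C/C(=C\c1ccc(N(C)C)cc1)C2=O` gives 13.2% in this assay. On these numbers compound 2 and compound 3 cannot be told apart, since their readings lie within the usual scatter, while compound 1 stands well above both of them, a gap beyond the scatter.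

The next compound, compound 4 `Cc1ccc2c(c1)C(=O)/C(=C/c1ccc(Cl)cc1)CN2CC(=O)O`, differs from compound 2 in a single place: chloro in place of fluoro on an aromatic carbon. For the measured compounds named here, no pair of measured compounds shows what this particular swap does, so there is no measured step to lean on. Compound 4 is expected to give about 20% in this assay, most likely between 5% and 40%. That amounts to an expected step of a number 3.9 percentage points higher from compound 2 to compound 4 (within the scatter), small and not clearly beyond the scatter in either direction.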

Compound 4, a percentage reported as inhibition, at one concentration (the size of the read-out at that concentration, not a potency): 20.7%
Compound 4: middle estimate off by 0.7 percentage points, on the low side; low and high end bracket the measured number.
By their numbers in this assay, from the lowest: compounds 3, 2 and 4 (each within the scatter of the next); then compound 1.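

The swap of 4-fluorophenyl to 4-chlorophenyl gives a number 4.6 percentage points higher from compound 2 to compound 4 (within the scatter) in this assay. For the compounds shown here, this pair is the first in the set to differ in one place only, and it shows that on this aromatic carbon, para to a large group, fluoro and chloro cannot be told apart by this read-out. Nothing measured here speaks to why the two compounds read alike.

On these data alone, whether this position responds at all to a larger change remains open, as a bromo, a methoxy, a nitrile or a carboxylic acid on the same aromatic carbon could still give a step beyond the scatter. As far as these compounds go, it is also open whether the same swap of fluoro for chloro would read the same way with the methyl group of compound 2 kept in place but the aromatic ring carrying its halogen elsewhere.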